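The compounds below may be only part of what the source reports. "The series", "measured", "known", "first", "only" and "open" are said of these compounds alone.

Measured so far in a functional assay on MCF7 cells (Homo sapiens) for inhibition, read by fluorescence, with a stated time of 72 h; a higher number here means a weaker inhibitor, a lower number a stronger inhibitor:
Compound 1 `CC[C@H](CO)Nc1nc(NC(=N)N)c2ncn(C(C)C)c2n1`: 4500 nM
Compound 2 `CC(C)n1cnc2c(NC(=N)N)nc(OC[C@@H]3CCCN3)nc21`: > 100000 nM (a limit)

Compound 2 stands at the limit of > 100000 nM in this assay, at which 1 of the 2 values shown sits, and this is a limit rather than a number.

Compound 3 `CC(C)n1cnc2c(NC(=N)N)nc(OC[C@H]3CCCN3)nc21` has the same atoms and bonds as compound 2, and only its drawn configuration differs: the two compounds have the same atoms and bonds; at least one stereo element is drawn with a configuration in one of them and without one in the other: 1 of 2 stereo elements differ; a stereocentre at a saturated ring carbon is drawn S in compound 2 and R in compound 3.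

Going by the values given here, one measured step bears on this, and only loosely. The large step of an at least 22-fold higher number from compound 1 to compound 2 (1.34 log units; beyond the scatter) replaces a whole group, so it says nothing about a change of configuration at a saturated ring carbon. Compound 3 keeps the (pyrrolidin-2-yl)methoxy group, so a return towards compound 1 at 4500 nM is not expected. No change beyond the scatter is expected, and the assay may again report only a limit.

The estimated change is a number no higher from compound 2 to compound 3 (the limit leaves the size open).

For compound 3 the expected value is 100000 nM, with an estimated range from 25000 nM to 200000 nM.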

Compound 3, half-maximal inhibitory concentration: > 100000 nM
Compound 3 gave a limit, no number; the forecaster's own chance of this, stated with the estimate: 70%; the middle value sits exactly at the limit.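

In this assay compound 3 gives > 100000 nM, which is a limit and not a number. Neither drawn configuration at the saturated ring carbon brings a measured number into view, and the step between compound 2 and compound 3 cannot be read: the limit of > 100000 nM in this assay, at which 2 of the 3 values shown sit. The (pyrrolidin-2-yl)methoxy group in this second configuration also shows an at least 22-fold higher number from compound 1 to compound 3 (1.34 log units; beyond the scatter).

Any difference between the two configurations stays hidden behind the limit, so the change of configuration may matter or may not. Also open, on these data alone, is which part of the (pyrrolidin-2-yl)methoxy group goes with the loss, and how a simple amine or a longer chain on the same aromatic carbon would read in this assay.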